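Adding one methyl to compound 2

The compounds below may be only part of what the source reports. "The series", "measured", "known", "first", "only" and "open" are said of these compounds alone.

Compound 1 (`COc1cc(C)ccc1COc1ccc2c(c1)CCC(CN1CC(C(=O)O)C1)=C2C`): > 0.1 mg/kg (a limit)
Compound 2 (`CCCc1ccc(COc2ccc3c(c2)CCC(CN2CC(C(=O)O)C2)=C3C)c(OC)n1`): 0.011 mg/kg

In a functional assay on the whole organism (strain BALB/c) with Mus musculus as the target, with a stated time of 4 h (on this read-out higher numbers stand for an effect only at larger amounts of compound and lower numbers for an effect already at smaller amounts), compound 1 gives > 0.1 mg/kg, which is a limit of the assay and not a number. In this assay, within the data shown here, compound 2 gives 0.011 mg/kg, the only actual number so far.

Compound 3 (`CCCc1ccc(COc2ccc3c(c2C)CCC(CN2CC(C(=O)O)C2)=C3C)c(OC)n1`) differs from compound 2 in one place (methyl in place of hydrogen on an aromatic carbon): methyl in place of hydrogen on an aromatic carbon, ortho to a fused ring and ortho to a large group. Among the measured compounds shown here, no measured step yet shows what such a change does in this assay. Starting from compound 2 at 0.011 mg/kg, a shift no larger than the usual scatter is expected, if anything toward a slightly larger dose. The estimated step is a 1.4-fold higher number from compound 2 to compound 3 (0.13 log units; within the scatter) in size. For compound 3 the expected dose is 0.015 mg/kg, with an estimated range from 0.004 mg/kg to 0.06 mg/kg at its ends.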

Compound 3, dose for half-maximal effect: 0.017 mg/kg
The estimate for compound 3 lay 1.1-fold (0.05 log units) below the measured number, and the stated range covers the measured number.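

Methyl in place of hydrogen on an aromatic carbon, ortho to a fused ring and ortho to a large group, gives a 1.5-fold higher number from compound 2 to compound 3 (0.19 log units; within the scatter) in this assay and so produces no shift that can be told apart from the usual scatter. Among these compounds, this single pair is the first measured sign that this position of the shared core can carry one added carbon while the effect still appears at a dose that is indistinguishable from the dose of the parent compound. Nothing among the data shown explains why the added methyl makes so little difference.

As far as these compounds go, whether this position would accept a different group remains open: chlorine, a hydroxyl, an amine or a longer chain such as ethyl could give a different result. One pair also says nothing about the other aromatic carbons of the core.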